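Chloro for Phenyl on a Shared Core: Expected Inhibition

This account rests on a few compounds, and the source may have more. Where it says the series, first, only, none or still open, it means among the compounds named here.

Measured compounds:
compound 1, `CCc1ccc(-c2nc3ccccn3c2Sc2ccccc2)cc1`, gives > 100000 nM in an ADME assay on NIH3T3 cells (Mus musculus) for inhibition, read by MTT assay, with a stated time of 48 h; on this read-out lower numbers stand for stronger inhibition and higher numbers for weaker inhibition.
compound 2, `c1ccc(Sc2c(-c3cccc4ccccc34)nc3ccccn23)cc1`, gives > 100000 nM in this assay.
compound 3, `c1ccc(Sc2c(-c3ccccc3)nc3ccc(-c4ccccc4)cn23)cc1`, gives > 100000 nM in this assay.

Each of these three values is a limit of the assay, not a number: the compounds showed no inhibition up to the highest concentration tested. Compound 3 therefore stands at the limit, and so do the other two, as the evidence shows: the limit of > 100000 nM in this assay, at which 3 of the 3 values shown sit. For the measured compounds named here, no step between two measured compounds is available, so nothing here says how a change on the core shifts the read-out.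

Compound 4, `Clc1ccc2nc(-c3ccccc3)c(Sc3ccccc3)n2c1`, differs from compound 3 in one place: chloro in place of phenyl on an aromatic carbon. With every measured compound sitting at the limit, there is no ground to expect a change beyond the usual scatter. The step from compound 3 to compound 4 is therefore expected to be a step that the limit leaves unreadable from compound 3 to compound 4, meaning no real movement. For compound 4 the estimated value in this assay is 150000 nM, with an expected range from 50000 nM to 500000 nM, and most likely the assay will again report only a limit.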

Compound 4, half-maximal inhibitory concentration: > 100000 nM
Compound 4 ended at the assay's limit; the forecaster's own chance of this, stated with the estimate: 85%; the middle value is on the limit's open side.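

Compound 3 and compound 4 both end at a limit of the assay rather than at a number, so no step between them can be read: the limit of > 100000 nM in this assay, at which 4 of the 4 values shown sit.

The compounds shown leave open whether any change on the shared core would give a real number in this assay rather than a limit.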